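A few compounds are considered here, and "the series" means these few. Any claim that something is new, unique, unknown or untested is made for them only; others in the source may bear on it.

Measured compounds:
- Compound 1, `CN(C(=O)NC(=O)c1ccc(Cl)cc1Cl)c1nc(C(F)(F)F)c(C(=O)N/N=C/c2cccc(C(F)(F)F)c2)s1`: in a functional assay on A549 cells (Homo sapiens) for inhibition, read by MTT assay, with a stated time of 72 h (on this read-out higher numbers stand for weaker inhibition and lower numbers for stronger inhibition), compound 1 gives 10.6 ug/mL.
- Compound 2, `CN(C(=O)NC(=O)c1ccc(Cl)cc1Cl)c1nc(C(F)(F)F)c(C(=O)N/N=C/c2ccc(C(F)(F)F)cc2)s1`: in this assay compound 2 gives 9.4 ug/mL.
- Compound 3, `CN(C(=O)NC(=O)c1ccc(Cl)cc1Cl)c1nc(C(F)(F)F)c(C(=O)N/N=C/c2ccccc2C(F)(F)F)s1`: in this assay compound 3 gives 15.3 ug/mL.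

These three compounds share one core and differ only in where the trifluoromethyl group sits on the phenyl ring attached to the carbon with a double bond to nitrogen. Among the compounds with values here, the numbers lie close together: the step of a 1.1-fold lower number from compound 1 to compound 2 (0.05 log units; within the scatter), the step of a 1.4-fold higher number from compound 1 to compound 3 (0.16 log units; within the scatter) and the step of a 1.6-fold higher number from compound 2 to compound 3 (0.21 log units; within the scatter) all fall inside the usual scatter, so no compound can be called stronger or weaker than another.

Compound 4, `CN(C(=O)NC(=O)c1ccccc1F)c1nc(C(F)(F)F)c(C(=O)N/N=C/c2ccc(C(F)(F)F)cc2)s1`, has not been measured. It keeps the trifluoromethylphenyl group of compound 2 and instead changes the other end of the molecule: 2-fluorophenyl in place of 2,4-dichlorophenyl on a carbonyl carbon. Within the data shown here, none of the measured steps touches this part of the structure, so they give no direct guide to the size or direction of the change. The expectation for compound 4 therefore rests on the observation that the three measured values cluster closely; the estimated step of a 1.5-fold higher number from compound 2 to compound 4 (0.17 log units; within the scatter) is small, with a wide range to reflect the missing evidence. Compound 4 is expected to give about 14 ug/mL, between 6 ug/mL and 35 ug/mL.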

Compound 4, half-maximal inhibitory concentration: 5.68 ug/mL
Estimate against measurement, compound 4: 2.5-fold (0.39 log units) above; measured number outside the range, below it.
By their numbers in this assay, from the lowest: compounds 4, 2, 1 and 3 (each within the scatter of the next, the first and the last beyond it).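

Swapping 2,4-dichlorophenyl for 2-fluorophenyl on a carbonyl carbon is the only change shown at this end of the molecule, and in this assay it gives a 1.7-fold lower number from compound 2 to compound 4 (0.22 log units; within the scatter), so compound 2 and compound 4 cannot be told apart. This position therefore accepts a different substitution pattern on the phenyl ring, with both chlorines gone and one fluorine present, without a change beyond the scatter. Nothing available explains this result or connects it to any property of either group.

From the compounds shown here alone, it remains open whether a carbonyl carbon bearing something other than a substituted phenyl, such as an amine, a carboxylic acid or a longer alkyl chain, would be accepted as well. Also unknown is whether 2-fluorophenyl would give a similar step alongside the trifluoromethylphenyl groups of compound 1 and compound 3.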